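The source may hold more compounds than are shown below. What is called first, only, known or untested is meant among the compounds shown, and "the series" means these compounds.

In an ADME assay on HEK293 cells (Homo sapiens) for cytotoxicity, read by resazurin assay, with a stated time of 72 h (a higher number here means that more compound is tolerated, a lower number that less compound is tolerated), three compounds sharing one core have been measured: compound 1 `COc1cc(CNC(=O)c2nc3ccc(F)c(OCCc4ccc(C(=O)O)cc4)c3c(=O)[nH]2)ccc1F`, compound 2 `O=C(O)c1ccc(CCOc2c(F)ccc3nc(C(=O)NCc4cccc(C5CC5)c4)[nH]c(=O)c23)cc1` and compound 3 `CCc1ccc(CNC(=O)c2nc3ccc(F)c(OCCc4ccc(C(=O)O)cc4)c3c(=O)[nH]2)cc1`. Compound 1 gives > 20000 nM, which is a limit of the assay and not a number. Compound 2 gives > 20000 nM, again a limit. Compound 3 gives > 20000 nM, also a limit. Compound 3 therefore stands with the other two, at the limit of > 20000 nM in this assay, at which 3 of the 3 values shown sit.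

Compound 4 `CCc1cccc(CN(C)C(=O)c2nc3ccc(F)c(OCCc4ccc(C(=O)O)cc4)c3c(=O)[nH]2)c1` has not yet been measured. Its difference from compound 3 is (3-ethylbenzyl)(methyl)amino in place of (4-ethylbenzyl)amino on a carbonyl carbon. In words, (3-ethylbenzyl)(methyl)amino comes in place of (4-ethylbenzyl)amino on a carbonyl carbon.

Among the measured compounds shown here, three measured steps bear on this change, all swaps among 4-ethylphenyl, 3-cyclopropylphenyl and 4-fluoro-3-methoxyphenyl. For the measured compounds named here, the first is a step that the two limits leave unreadable from compound 2 to compound 3. The second is a step that the two limits leave unreadable from compound 1 to compound 3. The third is a step that the two limits leave unreadable from compound 1 to compound 2. Going by the values given here, none of them has a size that can be read, and no measured compound carries (3-ethylbenzyl)(methyl)amino. Among the compounds with values here, they show only that all three compounds end at the same limit.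

No step beyond the usual scatter is expected in this assay, and no direction can be expected either. The expected change is a step that the limit leaves unreadable from compound 3 to compound 4. The estimate for compound 4 is 25000 nM, with an expected range from 10000 nM to 60000 nM.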

Compound 4, half-maximal cytotoxic concentration: > 20000 nM
Compound 4 ended at the assay's limit (the forecaster's own chance of this, stated with the estimate: 85%); the middle value lies beyond the limit too.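

In this assay compound 4 gives > 20000 nM and this is a limit, not a number. Among the compounds shown here, no step from compound 1, compound 2 or compound 3 to compound 4 can be read, because all four compounds end at the same limit: the limit of > 20000 nM in this assay, at which 4 of the 4 values shown sit. The compounds shown leave open at what concentration, if any, each would harm these cells.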